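The compounds below may be only part of what the source reports. "The series", "measured", "known", "first", "only" and "open" are said of these compounds alone.

Measured in a functional assay on HT-29 cells (Homo sapiens) for antiproliferative activity, read by sulforhodamine B assay, with a stated time of 48 h (a higher number here means a weaker inhibitor, a lower number a stronger inhibitor), so far:
- Compound 1 `Cc1cccc(OS(=O)(=O)c2ccc(N3CCN(C)C3=O)cc2)c1` gives 4300 nM
- Compound 2 `CN1CCN(c2ccc(S(=O)(=O)Oc3cccc(F)c3)cc2)C1=O` gives > 100000 nM as a limit

Compound 2 stands at > 100000 nM as a limit of the assay, not as a number. Compound 3 `Cc1ccc(OS(=O)(=O)c2ccc(N3CCN(C)C3=O)cc2)cc1` has 4-methylphenyl in place of 3-fluorophenyl on an oxygen. Within the data shown here, the one measured step that bears on this, an at least 23-fold higher number from compound 1 to compound 2 (1.36 log units; beyond the scatter), was large and beyond the scatter, with fluoro in place of methyl on an aromatic carbon. Compound 3 carries a methyl again, as compound 1 does. The large step expected here is estimated as an at least 16-fold lower number from compound 2 to compound 3 (1.22 log units; beyond the scatter), which would mean a stronger inhibitor. For compound 3 the estimate is 6000 nM, with an expected range from 1500 nM to 30000 nM.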

Compound 3, half-maximal inhibitory concentration: > 100000 nM
Compound 3 gave a limit, no number; the forecaster's own chance of this, stated with the estimate: 15%; middle value at least 16-fold (1.22 log units) from the limit.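

In this assay, 4-methylphenyl in place of 3-methylphenyl on the oxygen gives an at least 23-fold higher number from compound 1 to compound 3 (1.36 log units; beyond the scatter). A methyl on this aryl group therefore does not by itself keep the activity, and among the three compounds only compound 1, with 3-methylphenyl, gives a number. Compound 3 gives > 100000 nM, a limit of this assay and not a number, so its step from compound 2 cannot be read: the limit of > 100000 nM in this assay, at which 2 of the 3 values shown sit.

On these data alone, whether 3-fluorophenyl and 4-methylphenyl differ at all stays open. So does what a methoxy group or a chlorine in place of the methyl of compound 1 would give.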